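A few compounds are considered here, and "the series" means these few. Any claim that something is new, unique, unknown or untested is made for them only; others in the source may bear on it.

Compound 1 `CCN1C(=O)CS/C1=N/Nc1nncc2ccccc12`: 6 nM
Compound 2 `O=S(=O)(Nc1nccs1)c1ccc(Nc2nncc3ccccc23)cc1`: 45 nM
Compound 3 `O=C1CS/C(=N/Nc2nncc3ccccc23)N1`: 6 nM

All three compounds were tested in a functional assay on SF-268 cells (Homo sapiens) for antiproliferative activity, read by sulforhodamine B assay, with a stated time of 72 h; on this read-out lower numbers stand for stronger inhibition and higher numbers for weaker inhibition. Compound 2, at 45 nM, has the highest number of the three, and the other two both lie lower by more than the usual scatter.

The next compound to be measured is compound 4 `NS(=O)(=O)c1ccc(Nc2nncc3ccccc23)cc1`. It differs from compound 2 as follows: hydrogen in place of 1,3-thiazol-2-yl on a sulfonamide nitrogen. In other words, hydrogen takes the place of 1,3-thiazol-2-yl on a sulfonamide nitrogen.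

Going by the values given here, only one measured step also swaps a group for hydrogen, and it shows no change at the digits printed from compound 1 to compound 3 (within the scatter). There, hydrogen replaces ethyl on an amide-type nitrogen in a ring. Among the compounds with values here, that is a different group in a different setting, so it is only a loose guide, and no measured step removes the 1,3-thiazol-2-yl group itself. A shift beyond the scatter in either direction therefore cannot be ruled out, but none is expected.

The expected result is a 1.1-fold lower number from compound 2 to compound 4 (0.05 log units; within the scatter). For compound 4 the estimate in this assay is 40 nM, with an expected range from 10 nM to 180 nM.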

Compound 4, half-maximal inhibitory concentration: 33 nM
Estimate against measurement, compound 4: 1.2-fold (0.08 log units) above, within the range that was stated.
By their numbers in this assay, from the lowest: compounds 1 and 3 (each within the scatter of the next); then compounds 4 and 2 (each within the scatter of the next).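

In this assay, taking the 1,3-thiazol-2-yl group off the sulfonamide nitrogen gives a 1.4-fold lower number from compound 2 to compound 4 (0.13 log units; within the scatter), so this whole ring can be replaced by hydrogen with no shift that stands clear of the scatter. Going by these compounds alone, the earlier compounds gave no reading at this nitrogen: their only step, no change at the digits printed from compound 1 to compound 3 (within the scatter), swaps ethyl for hydrogen on an amide-type nitrogen in a ring, and the two steps now agree in showing no shift beyond the scatter. No measurement here explains why the number holds when the ring is removed.

Going by these compounds, whether a methyl or acetyl group on this nitrogen, or a carboxylic acid in place of the sulfonamide, would hold the number as well remains open. Compound 4 differs from compounds 1 and 3 in more than one place, so no single change links them.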